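Substituent swap on the benzamide of an ethylpiperazinyl quinoline

A few compounds are considered here, and "the series" means these few. Any claim that something is new, unique, unknown or untested is made for them only; others in the source may bear on it.

Three compounds share a quinoline core bearing a methyl group and an amide-linked aryl ring, and all were tested in a functional assay on MCF7 cells (Homo sapiens) for antiproliferative activity, read by MTT assay, with a stated time of 72 h; a lower number here means a stronger inhibitor, a higher number a weaker inhibitor. Compound 1 `CNc1cc(C)c2cc(NC(=O)c3ccc(Cl)c(Cl)c3)ccc2n1` gives 2520 nM. Compound 2 `CCN1CCN(c2cc(C)c3cc(NC(=O)c4ccccc4F)ccc3n2)CC1` gives 32600 nM, and compound 3 `CCN1CCN(c2cc(C)c3cc(NC(=O)c4ccccc4Br)ccc3n2)CC1` gives 27500 nM. Compound 3 thus stands second highest of the three numbers: it sits close to compound 2, while compound 1 shows a markedly lower number, though compound 1 differs from compound 3 in more than one place, so that gap cannot be tied to a single change.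

Compound 4 `CCN1CCN(c2cc(C)c3cc(NC(=O)c4ccc(OC)cc4)ccc3n2)CC1` has not yet been measured. It differs from compound 3 by 4-methoxyphenyl in place of 2-bromophenyl on a carbonyl carbon. Among the compounds with values here, the only measured step that bears on this position is a 1.2-fold lower number from compound 2 to compound 3 (0.07 log units; within the scatter), which changed the same aryl group and stayed within the scatter. That single step gives little reason to expect a large move, and nothing measured here speaks to a methoxy group on this ring. The expectation is therefore a step of about a 1.1-fold lower number from compound 3 to compound 4 (0.04 log units; within the scatter), meaning essentially no change beyond the scatter. Compound 4 is accordingly estimated at 25000 nM, with a range from 8000 nM to 80000 nM.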

Compound 4, half-maximal inhibitory concentration: 7690 nM
The estimate for compound 4 lay 3.3-fold (0.51 log units) above the measured number, and the stated range ends above it.
By their numbers in this assay, from the lowest: compound 1; then compound 4; then compounds 3 and 2 (each within the scatter of the next).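

The earlier swap on this aryl group, a 1.2-fold lower number from compound 2 to compound 3 (0.07 log units; within the scatter), suggested that the number in this assay might barely respond to changes here, but the new result shows that it can. Replacing 2-bromophenyl with 4-methoxyphenyl on the carbonyl carbon gives a 3.6-fold lower number from compound 3 to compound 4 (0.55 log units; beyond the scatter), and replacing 2-fluorophenyl with the same group gives a 4.2-fold lower number from compound 2 to compound 4 (0.63 log units; beyond the scatter), so both steps lie beyond the scatter, though both are modest, and compound 4 separates from the two halogen compounds. No measurement here explains why the number falls with this change, so the result records an effect without giving its cause.

The step changes both the group and its numbered place on the ring, so a 4-bromophenyl or a 2-methoxyphenyl partner would be needed to tell which of the two matters. Also open, as far as these compounds go, is how this aryl position would respond to a quite different group, such as an amine or a carboxylic acid, and whether a 4-methoxyphenyl would give a similar step on a core carrying something other than the ethylpiperazine.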